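A few compounds are considered here, and "the series" means these few. Any claim that something is new, unique, unknown or untested is made for them only; others in the source may bear on it.

In an ADME assay on the whole organism for inhibition, with Oryza sativa as the target, with a stated time of 4 days (a lower number here means a stronger inhibitor, a higher number a weaker inhibitor), compound 1 (`CC[C@H](C)Nc1nc(Cl)nc(N[C@@H](C)c2ccccc2)n1`) gives 6920 nM and compound 2 (`CC[C@@H](C)Nc1nc(Cl)nc(N[C@@H](C)c2ccccc2)n1`) gives 9770 nM, so compound 2 stands within the scatter of compound 1. Compound 3 (`CCC(CC)Nc1nc(Cl)nc(N[C@@H](C)c2ccccc2)n1`) carries pentan-3-yl in place of sec-butyl on a nitrogen on an aromatic ring. Within the data shown here, the only measured step, a 1.4-fold higher number from compound 1 to compound 2 (0.15 log units; within the scatter), lies within the scatter, and it bears on this change only loosely, given (the fact that compounds 1 and 2 differ only in the configuration as drawn). Among the measured compounds shown here, no measured step replaces sec-butyl with another group, so the series offers no direct guide to this swap and the range is kept wide. The estimated 1.0-fold lower number from compound 2 to compound 3 (0.01 log units; within the scatter) stays small, with no step beyond the scatter expected in this assay in either direction. For compound 3 the expected value is 9500 nM, with an estimated range of 3500 nM to 25000 nM.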

Compound 3, half-maximal inhibitory concentration: 35500 nM
Estimate against measurement, compound 3: 3.7-fold (0.57 log units) below; the measured number lies above the stated range.
By their numbers in this assay, from the lowest: compounds 1 and 2 (each within the scatter of the next); then compound 3.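

At this place, on a nitrogen on an aromatic ring, exchanging the group itself moves the number in this assay, which the earlier pair could not show: pentan-3-yl in place of sec-butyl gives a 3.6-fold higher number from compound 2 to compound 3 (0.56 log units; beyond the scatter) and a 5.1-fold higher number from compound 1 to compound 3 (0.71 log units; beyond the scatter). The higher number appears from both sec-butyl compounds, so the direction of the swap does not rest on one drawn configuration at that chain carbon, and the starting pair is of this kind: the fact that compounds 1 and 2 differ only in the configuration as drawn. In this series, sec-butyl is therefore the better of the two groups at this nitrogen, by a step that the configuration change did not produce.

Only this one swap of the group is shown, so no trend with chain shape can be drawn from it. From the compounds shown here alone, how an unbranched pentyl chain, a smaller isopropyl group or a cyclopentyl ring would read at this nitrogen stays open.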